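A few compounds are considered here, and "the series" means these few. Any claim that something is new, unique, unknown or untested is made for them only; others in the source may bear on it.

Measured so far in a physicochemical assay for lipophilicity, using the shake flask method, in phosphate buffer, measured as octanol-water partition, with a stated time of 24 h, at pH 7.4, tested at 100 uM; a lower number here means a more polar compound, a higher number a more lipophilic compound:
- compound 1 `COc1cc(C)c(-c2cccc(COc3ccc(S(=O)(=O)CC(=O)O)cc3)c2)c(C)c1`: 2.45
- compound 2 `CCOc1cc(C)c(-c2cccc(COc3ccc(S(=O)(=O)CC(=O)O)cc3)c2)c(C)c1`: 2.86
- compound 3 `Cc1cc(OCC(C)C)cc(C)c1-c1cccc(COc2ccc(S(=O)(=O)CC(=O)O)cc2)c1`: 3.94

Compound 1 stands lowest of the three. Compound 4 `O=C(O)CS(=O)(=O)c1ccc(OCc2cccc(-c3ccccc3C(F)(F)F)c2)cc1` is still unmeasured. Its change from compound 1 is 2-(trifluoromethyl)phenyl in place of 4-methoxy-2,6-dimethylphenyl on an aromatic carbon, with 2-(trifluoromethyl)phenyl in place of 4-methoxy-2,6-dimethylphenyl on an aromatic carbon.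

The measured steps bear on this only indirectly. For the measured compounds named here, the modest a number 0.41 log units higher from compound 1 to compound 2 (beyond the scatter) and the large a number 1.49 log units higher from compound 1 to compound 3 (beyond the scatter) and a number 1.08 log units higher from compound 2 to compound 3 (beyond the scatter) all alter the chain on the oxygen, and no measured step replaces the whole group. No step beyond the scatter is therefore expected in this assay, in either direction, though the size of these steps keeps the range wide.

The expected change is a number 0.05 log units lower from compound 1 to compound 4 (within the scatter).

Compound 4 is estimated at 2.4, with an expected range of 1.8 to 3.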

Compound 4, distribution coefficient: 2.95
The estimate for compound 4 lay 0.55 log units below the measured number, and the stated range covers the measured number.
By their numbers in this assay, from the lowest: compound 1; then compounds 2 and 4 (each within the scatter of the next); then compound 3.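

Exchanging the whole group on this aromatic carbon, and not only the chain on the oxygen, also moves the number in this assay: 2-(trifluoromethyl)phenyl in place of 4-methoxy-2,6-dimethylphenyl gives a number 0.50 log units higher from compound 1 to compound 4 (beyond the scatter). The two groups hold the same count of heavy atoms, yet the step lies beyond the scatter. No measurement shown here accounts for this step.

The compounds shown do not separate the entry of trifluoromethyl from the loss of the methoxy and the two methyl groups. Also open, on these data alone, is how an unsubstituted phenyl or a 2-chlorophenyl group would read on this carbon.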